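The compounds below may be only part of what the source reports. "The series", "measured", "known", "first", "only" and "open" are said of these compounds alone.

In a functional assay, with a stated time of 10 min (on this read-out lower numbers stand for stronger inhibition and higher numbers for weaker inhibition), compound 1 `COc1ccc(-c2nc(SC)n(C)c(=O)c2C#N)cc1` gives 48 ug/mL, which is the second highest of the three numbers in hand. Nearest to it stands compound 3 `Cn1c(NN)nc(-c2ccco2)c(C#N)c1=O`, with 58 ug/mL; furthest stands compound 2 `COc1ccc(-c2nc(NN)n(C)c(=O)c2C#N)cc1`, with 32 ug/mL. Among the compounds with values here, the only step that can be read between two compounds differing in one place runs a 1.5-fold lower number from compound 1 to compound 2 (0.18 log units; within the scatter), where hydrazinyl replaces methylsulfanyl on an aromatic carbon of the shared core. Compound 4 `CSc1nc(-c2ccc(N(C)C)cc2)c(C#N)c(=O)n1C` differs from compound 1 elsewhere: dimethylamino in place of methoxy on an aromatic carbon. Within the data shown here, no measured pair changes this group, so nothing in the data bears directly on the change, and the one measured step, from compound 1 to compound 2, stays within the scatter. Compound 1 and compound 3 differ in two places and their values show only a gap within the scatter. The account therefore expects no step beyond the scatter in this assay, and the step of a 1.1-fold lower number from compound 1 to compound 4 (0.03 log units; within the scatter) is given as that expectation. For compound 4 the estimated value is 45 ug/mL, expected to fall between 20 ug/mL and 100 ug/mL.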

Compound 4, half-maximal inhibitory concentration: 84 ug/mL
Beside the measured number, compound 4's estimate is 1.9-fold (0.27 log units) below it, and the stated range covers the measured number.
By their numbers in this assay, from the lowest: compounds 2, 1, 3 and 4 (each within the scatter of the next, the first and the last beyond it).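

In this assay, within the data shown here, the exchange of methoxy for dimethylamino, on an aromatic carbon of a six-membered aromatic ring of carbon only and para to a large group, gives the first reading at this position: a 1.8-fold higher number from compound 1 to compound 4 (0.24 log units; within the scatter). For this one change the read-out therefore does not separate the two groups, and the step stays within the scatter, as the earlier step at the methylsulfanyl place also did. No measurement of any other kind bears on this result.

As far as these compounds go, whether this position matters at all stays open, since a group of another kind there, such as a carboxylic acid, a primary amine or a longer alkoxy chain, could give a step beyond the scatter or none. The compounds shown also leave open whether dimethylamino would read the same with hydrazinyl in place of methylsulfanyl on the shared core.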